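Chloro in Place of Trifluoromethyl on Sulfonamide Benzoxazole Compounds

The source may report more compounds than this note shows. Statements on the series, on what has been measured and on what is new or still open speak of the compounds shown alone.

Measured so far:
Compound 1 `O=S(=O)(Nc1ccc(-c2nc3ccccc3o2)cc1)c1ccc(F)c(C(F)(F)F)c1` reaches only a limit in an assay on isolated protein for inhibition of malate dehydrogenase, mitochondrial (Sus scrofa), with stated times of 45 min and 30 min (a lower number here means a stronger inhibitor, a higher number a weaker inhibitor), reported as > 63000 nM.
Compound 2 `O=S(=O)(Nc1ccc(-c2nc3ccccc3o2)cc1)c1cccc(C(F)(F)F)c1` likewise reaches only a limit, reported as > 63000 nM.
Compound 3 `O=S(=O)(Nc1ccc(-c2nc3ccccc3o2)cc1)c1ccc(Cl)c(C(F)(F)F)c1` also reaches only a limit, reported as > 63000 nM.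

All three compounds share one core and differ only in the groups on the sulfonyl-bearing ring. None of them gave a number in this assay; each sits at the limit of > 63000 nM in this assay, at which 3 of the 3 values shown sit. Compound 3 therefore stands nowhere in particular among the numbers shown: it is at the same limit as the other two, and no ordering among them can be read.

Compound 4 `O=S(=O)(Nc1ccc(-c2nc3ccccc3o2)cc1)c1ccc(Cl)c(Cl)c1` carries the change (chloro in place of trifluoromethyl on an aromatic carbon). The three measured steps, a step that the two limits leave unreadable from compound 1 to compound 2, a step that the two limits leave unreadable from compound 1 to compound 3 and a step that the two limits leave unreadable from compound 2 to compound 3, all run between limits and give no readable size in either direction. For the measured compounds named here, no measured step bears on the change with a number. With every neighbour at the limit, compound 4 is expected to remain there too, so the step that the limit leaves unreadable from compound 3 to compound 4 is estimated to be none beyond the scatter. For compound 4 the estimate is 100000 nM, within 30000 nM to 400000 nM, most likely reported again only as a limit.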

Compound 4, half-maximal inhibitory concentration: > 63000 nM
Compound 4: no number, only a limit; the forecaster's own chance of this, stated with the estimate: 85%; the middle value is on the limit's open side.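

Compound 3 and compound 4 both give only a limit in this assay, so the step between them cannot be read: the limit of > 63000 nM in this assay, at which 4 of the 4 values shown sit. The compounds shown leave open how strongly any of them inhibits the enzyme, and whether any change on the sulfonyl-bearing ring would give a measurable number.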